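The source may hold more compounds than are shown below. What is called first, only, known or untested is meant among the compounds shown, and "the series" means these compounds.

Measured so far in a functional assay on HepG2 cells (Homo sapiens) for antiproliferative activity, read by MTT assay, with a stated time of 72 h; on this read-out higher numbers stand for weaker inhibition and lower numbers for stronger inhibition
- compound 1 `Cc1ccc(-c2cn(C/C=C3\OC(=O)C(OCc4ccccc4)=C3OCc3ccccc3)nn2)cc1` gives > 100000 nM (a limit)
- compound 2 `CCCCc1cn(C[C@H](O)[C@H]2OC(=O)C(OCc3ccccc3)=C2OCc2ccccc2)nn1` gives 32800 nM
- compound 3 `O=C1O/C(=C\Cn2cc(-c3cc(C(F)(F)F)cc(C(F)(F)F)c3)nn2)C(OCc2ccccc2)=C1OCc1ccccc1` gives > 100000 nM (a limit)

Compound 2 is the only one of the three with a real number, 32800 nM. The other two values mark the limit of > 100000 nM in this assay, at which 2 of the 3 values shown sit, and carry no number of their own.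

Compound 4 `CC(C)(C)c1cn(C[C@H](O)[C@H]2OC(=O)C(OCc3ccccc3)=C2OCc2ccccc2)nn1` is the next case. It has tert-butyl in place of butyl on an aromatic carbon of a five-membered aromatic ring with 3 nitrogen (tert-butyl in place of butyl on an aromatic carbon). The two have the same atoms, joined differently.

Among the measured compounds shown here, no two measured compounds differ in only one place, so the series gives no direct size for such a change. No shift beyond the scatter is expected in this assay, with only a slight lean towards weaker inhibition. For the measured compounds named here, the single reference point is compound 2 at 32800 nM.

The expected 1.2-fold higher number from compound 2 to compound 4 (0.09 log units; within the scatter) is small. For compound 4 the estimated value is 40000 nM, with an expected range of 15000 nM to 100000 nM.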

Compound 4, half-maximal inhibitory concentration: 29200 nM
Estimate against measurement, compound 4: 1.4-fold (0.14 log units) above, within the range that was stated.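

In this assay, among the compounds shown here, tert-butyl in place of butyl on an aromatic carbon gives a 1.1-fold lower number from compound 2 to compound 4 (0.05 log units; within the scatter) and this is the first step that can be read. At this carbon of the five-membered aromatic ring with 3 nitrogen, the read-out does not tell apart the two arrangements of the same 4 carbon atoms. Steps to compound 1 and compound 3 cannot be read: the limit of > 100000 nM in this assay, at which 2 of the 4 values shown sit.

Left open is whether a longer chain such as octyl, an amine or a carboxylic acid at this carbon would give a number beyond the scatter of compound 2 and compound 4. Also open, going by these compounds, is what a phenyl group at this carbon gives on the core of compound 2, as compound 1 and compound 3 differ from compound 2 in more than one place.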